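The source may hold more compounds than are shown below. What is called first, only, known or untested is meant among the compounds shown, and "the series" means these compounds.

Working notes on the urea series. Compound 1 `CCN(CC)CCn1cnnc1-c1cc(Oc2ccc(NC(=O)Nc3ccc(Cl)c(C(F)(F)F)c3)cc2F)ccn1` and compound 2 `CCN(CC)CCn1cnnc1-c1cc(Oc2ccc(NC(=O)Nc3cccc(C(F)(F)F)c3)cc2F)ccn1` share the same core and differ only in hydrogen in place of chloro on an aromatic carbon. In a functional assay on NCI-H460 cells (Homo sapiens) for antiproliferative activity, read by MTT assay, with a stated time of 72 h (a lower number here means a stronger inhibitor, a higher number a weaker inhibitor), compound 1 gives 850 nM, and compound 2 gives 9870 nM. That single step reads a 12-fold higher number from compound 1 to compound 2 (1.06 log units; beyond the scatter), so compound 2 stands as the higher of the two numbers measured. Compound 3 `CCN(CC)CCn1cnnc1-c1cc(Oc2ccc(NC(=O)Nc3ccc(F)c(F)c3)cc2F)ccn1` is not yet measured; relative to compound 2 the change is 3,4-difluorophenyl in place of 3-(trifluoromethyl)phenyl on an amide-type nitrogen. Within the data shown here, no measured step covers this exchange directly; the only step known, from compound 1 to compound 2, concerns a different position of the same ring and shows that a substituent change there can move this assay by a large amount. Since compound 3 keeps a substituted ring but loses the trifluoromethyl group, the step of a 1.6-fold lower number from compound 2 to compound 3 (0.22 log units; within the scatter) is expected to be modest, within or near the scatter. Compound 3 is therefore estimated at 6000 nM with a range of 2000 nM to 20000 nM.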

Compound 3, half-maximal inhibitory concentration: 14900 nM
Estimate against measurement, compound 3: 2.5-fold (0.40 log units) below; the measured number falls inside the stated range.
By their numbers in this assay, from the lowest: compound 1; then compounds 2 and 3 (each within the scatter of the next).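

In this assay, replacing 3-(trifluoromethyl)phenyl with 3,4-difluorophenyl on the amide-type nitrogen gives a 1.5-fold higher number from compound 2 to compound 3 (0.18 log units; within the scatter), so this exchange on a ring without chloro leaves the reading within the scatter. The same 3,4-difluorophenyl group set against 4-chloro-3-(trifluoromethyl)phenyl gives an 18-fold higher number from compound 1 to compound 3 (1.24 log units; beyond the scatter), and among the three compounds only compound 1, the one ring carrying both chloro and trifluoromethyl, stands apart from the others. Nothing measured alongside these numbers accounts for that separation.

Open, from the compounds shown here alone, is whether 4-chlorophenyl or 3,4-dichlorophenyl on the same nitrogen would read like compound 1 or like compounds 2 and 3. Also open, going by these compounds, is whether bromo or methyl in place of the chloro of compound 1 would hold its number.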